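Swapping a Chain-End Amine on a Shared Core

The compounds below may be only part of what the source reports. "The series", "measured", "known", "first", "only" and "open" are said of these compounds alone.

Of the compounds shown here, three built on one shared core have been tested in a functional assay on SK-BR-3 cells (Homo sapiens) for antiproliferative activity, read by MTT assay, with a stated time of 72 h; a lower number here means a stronger inhibitor, a higher number a weaker inhibitor. Compound 1 `CCN(CC)CCNc1cc(C)c2cc(NC(=O)c3ccc(Cl)c(Cl)c3)ccc2n1` gives 3710 nM in this assay. Compound 2 `CCN1CCN(c2cc(C)c3cc(NC(=O)c4cc(Cl)cc(Cl)c4)ccc3n2)CC1` gives 2660 nM, and compound 3 `CCN1CCN(c2cc(C)c3cc(NC(=O)c4cc5ccccc5[nH]4)ccc3n2)CC1` gives 2550 nM. Compound 1 has the highest of the three numbers, yet its gaps to compound 2 and to compound 3 both lie within the scatter, so no order among them can be claimed. Going by the values given here, the only measured step between two compounds differing in one place, a 1.0-fold lower number from compound 2 to compound 3 (0.02 log units; within the scatter), changes the group on the carbonyl carbon and also stays within the scatter.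

Compound 4 `Cc1cc(NCCN2CCCCC2)nc2ccc(NC(=O)c3ccc(Cl)c(Cl)c3)cc12` differs from compound 1 in another part of the molecule: piperidin-1-yl in place of diethylamino on a saturated chain carbon, two bonds along the chain from a nitrogen on an aromatic ring. Among the compounds with values here, no measured step touches this chain-end amine, so there is nothing to suggest a shift in either direction. The step is therefore expected to be a 1.1-fold lower number from compound 1 to compound 4 (0.03 log units; within the scatter), within the scatter. Compound 4 is estimated at 3500 nM, with a range from 1500 nM to 8000 nM.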

Compound 4, half-maximal inhibitory concentration in the SK-BR-3 assay: 1800 nM
Estimate against measurement, compound 4: 1.9-fold (0.29 log units) above; measured number inside the range.
By their numbers in the SK-BR-3 assay, from the lowest: compounds 4, 3, 2 and 1 (each within the scatter of the next, the first and the last beyond it).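

Going by these compounds alone, in the SK-BR-3 assay the change from diethylamino to piperidin-1-yl gives a 2.1-fold lower number from compound 1 to compound 4 (0.31 log units; beyond the scatter) and so is the first measured step here to pass beyond the scatter, which shows that the chain-end amine can move this number, if only modestly. In a physicochemical assay for lipophilicity, at pH 7.4 (on this read-out higher numbers stand for higher lipophilicity and lower numbers for lower lipophilicity), compound 1 gives 1.66 and compound 4 gives 2.72 with the same change. Stronger inhibition thus comes together with higher lipophilicity in this one pair, though a single pair cannot show that one causes the other: the measured distribution coefficient of compound 1, 1.66, and of compound 4, 2.72, a number 1.06 log units higher (beyond the scatter)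

From the compounds shown here alone, it remains open whether the lower number follows the ring itself or the rise in lipophilicity. A morpholine or a pyrrolidine at the same chain end would help to separate the two.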